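Amide aryl change: compound 3 to compound 4

This account rests on a few compounds, and the source may have more. Where it says the series, first, only, none or still open, it means among the compounds named here.

Values in an ADME assay on MT4 cells (Homo sapiens) for cytotoxicity, read by MTT assay, with a stated time of 5 days; on this read-out higher numbers stand for lower toxicity in this test and lower numbers for higher toxicity in this test:
- compound 1 `COc1cc2nc([S+]([O-])CC(=O)Nc3cccc(F)c3)nc(Nc3c(Cl)cc(/C=C/C#N)cc3Cl)c2cc1OC`: 9550 nM
- compound 2 `COc1cc2nc([S+]([O-])CC(=O)Nc3cc([N+](=O)[O-])ccc3F)nc(Nc3c(Cl)cc(/C=C/C#N)cc3Cl)c2cc1OC`: > 194000 nM (a limit of the assay)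
- compound 3 `COc1cc2nc([S+]([O-])CC(=O)Nc3c(C)cc(C)cc3C)nc(Nc3c(Cl)cc(/C=C/C#N)cc3Cl)c2cc1OC`: 8870 nM
- compound 4 `COc1ccccc1NC(=O)C[S+]([O-])c1nc(Nc2c(Cl)cc(/C=C/C#N)cc2Cl)c2cc(OC)c(OC)cc2n1`: not yet measured

Compound 3 and compound 1 lie within the scatter of each other, with a 1.1-fold lower number from compound 1 to compound 3 (0.03 log units; within the scatter). Compound 2 gives no number, only (the limit of > 194000 nM in this assay, at which 1 of the 3 values shown sits). The next change is 2-methoxyphenyl in place of 2,4,6-trimethylphenyl on an amide-type nitrogen, (2-methoxyphenyl in place of 2,4,6-trimethylphenyl on an amide-type nitrogen). The large steps, an at least 20-fold higher number from compound 1 to compound 2 (1.30 log units; beyond the scatter) and an at least 21-fold lower number from compound 2 to compound 3 (1.33 log units; beyond the scatter), both involve 2-fluoro-5-nitrophenyl, which compound 4 lacks. The closer guide is a 1.1-fold lower number from compound 1 to compound 3 (0.03 log units; within the scatter), so no step beyond the scatter is expected in this assay. The expected change is a 1.1-fold higher number from compound 3 to compound 4 (0.05 log units; within the scatter). For compound 4 the estimated value is 10000 nM, with an expected range of 4000 nM to 40000 nM.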

Compound 4, half-maximal cytotoxic concentration: > 204000 nM
Compound 4: a limit, no number; the forecaster's own chance of this, stated with the estimate: 10%; middle value at least 20-fold (1.30 log units) away from the limit.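

In this assay, a large step at this amide-type nitrogen no longer needs 2-fluoro-5-nitrophenyl: 2-methoxyphenyl gives an at least 22-fold higher number from compound 3 to compound 4 (1.36 log units; beyond the scatter) and an at least 21-fold higher number from compound 1 to compound 4 (1.32 log units; beyond the scatter). The result for compound 4 is a limit, not a number: the limit of > 204000 nM in this assay, at which 1 of the 4 values shown sits.

Compound 2 also gives a limit, so the step between compound 2 and compound 4 cannot be read. As far as these compounds go, how 2-aminophenyl or 2-carboxyphenyl on the amide-type nitrogen would read remains open, as does whether 2-methylphenyl would follow 2-methoxyphenyl or 2,4,6-trimethylphenyl in this assay.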